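The source may report more compounds than this note shows. Statements on the series, on what has been measured and on what is new or still open speak of the compounds shown alone.

Measured compounds:
compound 1 `Nc1cc(N)c2nc(-c3ccccc3)c(NCc3ccc(Cl)c(Cl)c3)nc2c1`, 30200 nM
compound 2 `Nc1cc(N)c2nc(-c3ccccc3)c(Oc3ccc(F)cc3)nc2c1`, 32400 nM

Of the compounds shown here, two sharing one core have been tested in a functional assay on TK-10 cells (Homo sapiens) for inhibition, read by sulforhodamine B assay, with a stated time of 48 h; on this read-out lower numbers stand for stronger inhibition of growth and higher numbers for weaker inhibition of growth. Compound 1 gives 30200 nM, and compound 2 gives 32400 nM. The gap between these two numbers lies within the scatter of repeated measurements, so compound 1 cannot be told apart from compound 2 on these data; both sit in the same weak region of the read-out.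

The step considered here leads from compound 1 to compound 3 `COc1ccc(CNc2nc3cc(N)cc(N)c3nc2-c2ccccc2)cc1OC`, which has not yet been measured. The structural change is 3,4-dimethoxyphenyl in place of 3,4-dichlorophenyl on a saturated chain carbon bound to a nitrogen on an aromatic ring. The core, the phenyl group and the chain joining the aromatic nitrogen to the varied ring stay as they are; only the substituents on that varied ring change, from two chlorines to two methoxy groups.

Going by the values given here, no step between measured compounds involves such a change, so there is no direct guide to its size. With both measured values lying close together, the change from compound 1 to compound 3 is expected to move the number by no more than the scatter, in either direction. The expected step is a 1.2-fold higher number from compound 1 to compound 3 (0.08 log units; within the scatter). Compound 3 is therefore estimated at 36000 nM in this assay, with a range from 12000 nM to 100000 nM.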

Compound 3, concentration for total growth inhibition: 32400 nM
Compound 3: middle estimate off by 1.1-fold (0.05 log units), on the high side; low and high end bracket the measured number.
By their numbers in this assay, from the lowest: compounds 1, 2 and 3 (each within the scatter of the next).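

The swap of 3,4-dichlorophenyl for 3,4-dimethoxyphenyl, on a saturated chain carbon bound to a nitrogen on an aromatic ring, gives in this assay a 1.1-fold higher number from compound 1 to compound 3 (0.03 log units; within the scatter), so compound 1 and compound 3 cannot be told apart. This is the first direct test of this position among the compounds shown: the entering group has 10 heavy atoms against 8 and counts 2 hydrogen-bond acceptors against 0, yet the two numbers remain in the same weak region of the read-out. No separate measurement is available that could explain this result.

Going by these compounds alone, one pair shows only that these two substituted rings cannot be told apart, and it leaves open whether any group on this ring can carry the number out of the weak region. A carboxylic acid or an amine on the ring, an unsubstituted phenyl, or a longer chain between the ring and the aromatic nitrogen would each probe this position in a way that these compounds do not.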